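Series notes: amide nitrogen substituent on the thienylmethyl aryloxyacetamides

This account rests on a few compounds, and the source may have more. Where it says the series, first, only, none or still open, it means among the compounds named here.

Of the compounds shown here, two of the shared core carry numbers so far. Compound 1, `CCN(Cc1cccs1)C(=O)COc1ccccc1`, gives 1400 nM in an assay on HEK293 cells for agonist activity at transient receptor potential cation channel subfamily M member 8 (Homo sapiens), read by fluorescence and calcium flux, with a stated time of 15 min; a higher number here means that more compound is needed for the effect, a lower number that less compound is needed. Among the measured compounds shown here, compound 2, `CON(Cc1cccs1)C(=O)COc1ccc(C)cc1`, gives 10 nM in this assay, the lowest of the two values; the value of compound 1 lies far higher, beyond the scatter, though the two structures differ in more than one place, so no single step is drawn between them.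

Compound 3, `Cc1ccc(OCC(=O)N(CCO)Cc2cccs2)cc1`, has not yet been measured. It differs from compound 2 by 2-hydroxyethyl in place of methoxy on an amide-type nitrogen. For the measured compounds named here, no measured step matches this change, so the expectation rests on compound 2 alone. A moderate rise in the number is expected, meaning a step of a 15-fold higher number from compound 2 to compound 3 (1.18 log units; beyond the scatter), since this change touches the same nitrogen at which compound 2 gives 10 nM. Compound 3 is estimated at 150 nM, in the range 30 nM to 1000 nM.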

Compound 3, half-maximal effective concentration: 900 nM
For compound 3 the middle estimate is 6.0-fold (0.78 log units) below the measured one; low and high end bracket the measured number.
By their numbers in this assay, from the lowest: compound 2; then compounds 3 and 1 (each within the scatter of the next).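

Among the compounds shown here, putting 2-hydroxyethyl in place of methoxy on the amide-type nitrogen gives a 90-fold higher number from compound 2 to compound 3 (1.95 log units; beyond the scatter) in this assay as the only single-place step. The number therefore responds strongly to the group on this nitrogen, at least for this one exchange. The data shown offer no explanation for the size of this step.

Still open, as far as these compounds go, is whether the step follows the terminal hydroxyl or the chain itself. A 2-methoxyethyl or plain ethyl group on this nitrogen, on the core of compound 2, would begin to separate the two.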